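Adding a Second Chloro to the Aryl Ring of Compound 1

The source may hold more compounds than are shown below. What is called first, only, known or untested is meant among the compounds shown, and "the series" means these compounds.

Compound 1 `CC1CC(=O)N(CC(=O)N2CCN(c3cccc(Cl)c3)CC2)C1=O` was examined in a functional assay on the whole organism (strain CD1) with Mus musculus as the target, in the maximal electroshock model, with a stated time of 0.5 h (a lower number here means that less compound is needed, a higher number that more compound is needed for the effect), where compound 1 gives 100 mg/kg. Two companions share its core and differ only in the group on the aromatic ring: compound 2 `CCC1(C)CC(=O)N(CC(=O)N2CCN(c3ccccc3Cl)CC2)C1=O`, which in this assay gives 100 mg/kg, and compound 3 `CCC1(C)CC(=O)N(CC(=O)N2CCN(c3ccccc3C)CC2)C1=O`, which in this assay gives 100 mg/kg. Compound 1 therefore stands level with compounds 2 and 3 at the digits shown, all three within the scatter of one another. Going by the values given here, the single step that can be read among them, no change at the digits printed from compound 2 to compound 3 (within the scatter), left the minimum effective dose unchanged.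

Compound 4 `CC1CC(=O)N(CC(=O)N2CCN(c3ccc(Cl)c(Cl)c3)CC2)C1=O` differs from compound 1 by chloro in place of hydrogen on an aromatic carbon. Among the compounds with values here, no measured step adds a substituent to this ring; the one step available exchanges one substituent for another and shows no change, so the series gives no ground for a shift in either direction. Compound 4 is accordingly expected to give 100 mg/kg in this assay, with a range from 50 mg/kg to 200 mg/kg. The expected step is no change at the digits printed from compound 1 to compound 4 (within the scatter), nothing beyond the scatter.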

Compound 4, minimum effective dose: 300 mg/kg
Compound 4: middle estimate off by 3.0-fold (0.48 log units), on the low side, outside the stated range (above it).
By their numbers in this assay, from the lowest: compounds 1, 2 and 3 (each within the scatter of the next); then compound 4.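

Going from 3-chlorophenyl to 3,4-dichlorophenyl gives the first step in this series that lies beyond the scatter: in this assay it reads a 3.0-fold higher number from compound 1 to compound 4 (0.48 log units; beyond the scatter). The aromatic carbon ortho to a chloro group and para to a large group is therefore not indifferent to substitution, and chloro in place of hydrogen there means that more compound is needed for the effect, a modest step. The earlier exchange of methyl for chloro, no change at the digits printed from compound 2 to compound 3 (within the scatter), gave no sign of this, and nothing measured here accounts for the rise.

Whether the rise belongs to chloro itself or to any group on this carbon remains open, as fluoro, methyl and methoxy there are not among the compounds shown. Also open, going by these compounds, is whether the same added chloro would act alike on the core of compound 2.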